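Swapping a cyanomethyl for a cyanophenyl on the triazole arm

A few compounds are considered here, and "the series" means these few. Any claim that something is new, unique, unknown or untested is made for them only; others in the source may bear on it.

Measured so far:
- compound 1, `Cc1cc(C)c(Oc2cc(Nc3ccc(C#N)cc3)ncc2C(=O)NCc2cn(Cc3cccc([N+](=O)[O-])c3)nn2)c(C)c1`: >= 156000 nM
- compound 2, `COC(=O)Cn1cc(CNC(=O)c2cnc(Nc3ccc(C#N)cc3)cc2Oc2c(C)cc(C)cc2C)nn1`: 13800 nM
- compound 3, `Cc1cc(C)c(Oc2cc(Nc3ccc(C#N)cc3)ncc2C(=O)NCc2cn(CCC#N)nn2)c(C)c1`: 40200 nM

In an ADME assay on MT4 cells (Homo sapiens) for cytotoxicity, read by MTT assay, with a stated time of 5 days (a higher number here means that more compound is tolerated, a lower number that less compound is tolerated), compound 3 gives 40200 nM. Compound 1 reaches only a limit of this assay, >= 156000 nM, as noted in the limit of >= 156000 nM in this assay, at which 1 of the 3 values shown sits. Of the two plain numbers, compound 3 stands highest, ahead of compound 2 by a 2.9-fold higher number from compound 2 to compound 3 (0.46 log units; beyond the scatter).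

Compound 4, `Cc1cc(C)c(Oc2cc(Nc3ccc(C#N)cc3)ncc2C(=O)NCc2cn(Cc3cccc(C#N)c3)nn2)c(C)c1`, is not yet measured. It differs from compound 3 in one place: 3-cyanophenyl in place of cyanomethyl on a saturated chain carbon bound to an aromatic nitrogen.

The step that bears most directly on this change is the one in which the aryl group was removed: an at least 3.8-fold lower number from compound 1 to compound 3 (0.58 log units; beyond the scatter). Read in reverse, putting an aromatic ring back onto that chain carbon is accompanied by a higher number, and the 3-cyanophenyl entering here resembles the 3-nitrophenyl that left. The other large step, an at least 11-fold lower number from compound 1 to compound 2 (1.05 log units; beyond the scatter), points the same way. A higher number for compound 4 is therefore expected, with a real chance that this assay again reports only a limit.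

Compound 4 is estimated at 110000 nM, within a range of 45000 nM to 200000 nM, an expected step of a 2.7-fold higher number from compound 3 to compound 4 (0.44 log units; beyond the scatter).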

Compound 4, half-maximal cytotoxic concentration: >= 129000 nM
Compound 4 gave a limit, no number; the forecaster's own chance of this, stated with the estimate: 40%; at least 1.1-fold (0.06 log units) between middle value and limit.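

Putting an aromatic ring on the saturated chain carbon bound to an aromatic nitrogen gives an at least 3.2-fold higher number from compound 3 to compound 4 (0.50 log units; beyond the scatter) in this assay, and measured against the methoxycarbonyl compound the same position gives an at least 9.3-fold higher number from compound 2 to compound 4 (0.97 log units; beyond the scatter). The higher tolerance seen with the 3-nitrophenyl group of compound 1 is therefore not tied to the nitro group, since the 3-cyanophenyl group of compound 4 also stands clear of both compounds that carry no ring there. Compound 4 stops at a limit rather than a number, so how far the ring raises the tolerated concentration cannot be told: the limit of >= 129000 nM in this assay, at which 1 of the 4 values shown sits.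

Compound 1 also stops at a limit, which leaves the step between the nitro and cyano compounds unreadable: the limit of >= 156000 nM in this assay, at which 1 of the 4 values shown sits. The compounds shown also leave open whether the ring alone is enough, or whether its substituent matters, a question that a plain phenyl ring, or one carrying an amine or a carboxylic acid, would help to separate.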